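A few compounds are considered here, and "the series" means these few. Any claim that something is new, unique, unknown or untested is made for them only; others in the source may bear on it.

Measured so far in an ADME assay on HEL cells (Homo sapiens) for cytotoxicity; a higher number here means that more compound is tolerated, a lower number that less compound is tolerated:

compound 1, `O=C(COc1cccc2ccccc12)N/N=C/c1ccccc1Br`: 100 ug/mL
compound 2, `O=C(COc1cccc2ccccc12)N/N=C/c1ccccc1Cl`: 62.7 ug/mL
compound 3, `O=C(COc1cccc2ccccc12)N/N=C/c1ccc(Br)cc1`: 100 ug/mL

Compound 3 and compound 1 give the same number at the digits shown, and both stand where the numbers are largest; compound 2 is nearest to neither, as a 1.6-fold higher number from compound 2 to compound 3 (0.20 log units; within the scatter) shows. The next compound, compound 4, `COc1ccc(/C=N/NC(=O)COc2cccc3ccccc23)cc1`, carries the change (methoxy in place of bromo on an aromatic carbon). Going by the values given here, no measured step replaces a bromo by a methoxy, so nothing bears on it directly. The two steps that are known, a 1.6-fold lower number from compound 1 to compound 2 (0.20 log units; within the scatter) and no change at the digits printed from compound 1 to compound 3 (within the scatter), each stay within the scatter, which suggests that the shared core tolerates small changes on this ring without a visible move in this assay. Compound 4 is therefore expected to stay close to compound 3, with an expected step of no change at the digits printed from compound 3 to compound 4 (within the scatter). The estimate for compound 4 in this assay is 100 ug/mL, with a range from 50 ug/mL to 160 ug/mL.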

Compound 4, half-maximal cytotoxic concentration: 100 ug/mL
Estimate against measurement, compound 4: no gap at the digits printed, and the stated range covers the measured number.
By their numbers in this assay, from the lowest: compounds 2, 1, 3 and 4 (each within the scatter of the next).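

In this assay, going by these compounds alone, methoxy can take the place of bromo on the aromatic carbon para to a large group, with no change at the digits printed from compound 3 to compound 4 (within the scatter); this is the first group here that is not a halogen, and it brings the hydrogen-bond acceptor counted for methoxy. The comparisons with the other two compounds, a 1.6-fold higher number from compound 2 to compound 4 (0.20 log units; within the scatter) and no change at the digits printed from compound 1 to compound 4 (within the scatter), also stay within the scatter, so none of the four compounds is separated from the others by this read-out. No supporting measurement bears on why these groups are not told apart.

Going by these compounds, whether an amine, a carboxylic acid or a longer alkoxy chain at this place would also stay within the scatter remains open, as does the effect of such groups at the place that carries bromo in compound 1. The compounds also leave open whether changes to the shared core away from this ring would move the number.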